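Replacing a sulfonyl amino group with hydroxymethyl

The compounds below may be only part of what the source reports. "The series", "measured", "known", "first", "only" and "open" are said of these compounds alone.

Among the compounds with values here, in a functional assay on A549 cells (Homo sapiens) for antiproliferative activity, read by MTT assay, with a stated time of 72 h (on this read-out lower numbers stand for stronger inhibition and higher numbers for weaker inhibition), compound 1 (`O=C1O[C@H]([C@@H](O)Cn2cc(CCCCl)nn2)C(OCc2ccccc2)=C1OCc1ccccc1`) gives 29000 nM and compound 2 (`Cc1ccc(S(=O)(=O)NCc2cn(C[C@H](O)[C@H]3OC(=O)C(OCc4ccccc4)=C3OCc3ccccc3)nn2)cc1`) gives 16800 nM, so compound 2 stands within the scatter of its only measured neighbour. Compound 3 (`O=C1O[C@H]([C@@H](O)Cn2cc(CCO)nn2)C(OCc2ccccc2)=C1OCc1ccccc1`) carries hydroxymethyl in place of ((4-methylphenyl)sulfonyl)amino on a saturated chain carbon bound to an aromatic carbon. Within the data shown here, the one measured step bearing on this change, at the same place, is a 1.7-fold lower number from compound 1 to compound 2 (0.24 log units; within the scatter). On that evidence, no step beyond the scatter is expected in this assay. The expected step is a 1.5-fold higher number from compound 2 to compound 3 (0.17 log units; within the scatter). The estimate for compound 3 is 25000 nM, with a range of 11000 nM to 60000 nM.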

Compound 3, half-maximal inhibitory concentration: > 100000 nM
Compound 3: no number, only a limit (the forecaster's own chance of this, stated with the estimate: 15%); at least 4.0-fold (0.60 log units) between middle value and limit.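

Within the data shown here, this position is the first to move the read-out beyond the scatter, since compound 1 and compound 2 stood within it despite carrying very different groups. Hydroxymethyl in place of ((4-methylphenyl)sulfonyl)amino gives an at least 5.9-fold higher number from compound 2 to compound 3 (0.77 log units; beyond the scatter), and hydroxy in place of chloromethyl gives an at least 3.4-fold higher number from compound 1 to compound 3 (0.53 log units; beyond the scatter). Compound 3 gives only a limit, not a number: the limit of > 100000 nM in this assay, at which 1 of the 3 values shown sits.

From the compounds shown here alone, how far compound 3 lies past that limit stays open. So does whether an amine or a carboxylic acid at this chain end, or a longer chain ending in hydroxy, would read like compound 3 or like compound 2.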